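The source may report more compounds than this note shows. Statements on the series, on what has been measured and on what is new or still open speak of the compounds shown alone.

Working notes on the step from compound 2 `CC1(C)Oc2ccc(C#N)cc2[C@@H](/N=C(\NC#N)Nc2cccc(C(=O)O)c2)[C@@H]1O` to compound 3 `CC1(C)Oc2ccc(C#N)cc2[C@@H](/N=C(\NC#N)Nc2ccc(Cl)c(F)c2)[C@@H]1O`. In a functional assay (aorta) with Rattus norvegicus as the target (a higher number here means a weaker inhibitor, a lower number a stronger inhibitor), compound 2 gives > 100000 nM, which is a limit of the assay and not a number. Compound 2 therefore stands at the limit of > 100000 nM in this assay, at which 1 of the 2 values shown sits. Among the measured compounds shown here, the only other measured compound, compound 1 `COC(=O)c1ccc(N/C(=N/[C@@H]2c3cc(C#N)ccc3OC(C)(C)[C@H]2O)NC#N)cc1`, gives 18400 nM in this assay.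

The change under review is 4-chloro-3-fluorophenyl in place of 3-carboxyphenyl on an amine nitrogen, in words 4-chloro-3-fluorophenyl in place of 3-carboxyphenyl on an amine nitrogen. For the measured compounds named here, one measured step bears on it: an at least 5.4-fold higher number from compound 1 to compound 2 (0.73 log units; beyond the scatter), which lies beyond the scatter and brought in the same 3-carboxyphenyl at the same kind of nitrogen. Compound 3 loses that group, so a step in the opposite direction, towards a lower number in this assay, is expected. Going by the values given here, its size is poorly fixed, since the starting point is a limit and no measured compound carries 4-chloro-3-fluorophenyl. A step at least as large as the measured one is expected. The estimated change is an at least 25-fold lower number from compound 2 to compound 3 (1.39 log units; beyond the scatter). The estimate for compound 3 is 4000 nM, with an expected range of 500 nM to 30000 nM.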

Compound 3, half-maximal inhibitory concentration: 1660 nM
For compound 3 the middle estimate is 2.4-fold (0.38 log units) above the measured one; the range from low to high includes it.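

Against 4-(methoxycarbonyl)phenyl, 4-chloro-3-fluorophenyl on the amine nitrogen gives in this assay an 11-fold lower number from compound 1 to compound 3 (1.04 log units; beyond the scatter), so this position can move the number downwards as well as upwards, which compounds 1 and 2 alone could not show. Against 3-carboxyphenyl, the same group gives an at least 60-fold lower number from compound 2 to compound 3 (1.77 log units; beyond the scatter), and this bounded step sets the measured range at this position wider than the earlier pair did, with a halogenated phenyl at its lower end. Compound 2 stands at a limit of the assay and not at a number, so the true size of this step stays unknown: the limit of > 100000 nM in this assay, at which 1 of the 3 values shown sits.

The compounds shown leave open how the step divides between the chlorine and the fluorine, since compound 3 differs from both earlier compounds in its whole phenyl substituent and a phenyl with either halogen alone would be needed to separate them. Also open, on these data alone, is how an unsubstituted phenyl, or a phenyl bearing a trifluoromethyl group or an amine, would compare on the same nitrogen.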